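The compounds below may be only part of what the source reports. "The series", "measured", "known", "first", "only" and "open" are said of these compounds alone.

Among the compounds with values here, only two compounds have been measured so far in a physicochemical assay for lipophilicity, read by HPLC, in phosphate buffer, measured as octanol-water partition, with a stated time of 1 h, at pH 7.4; on this read-out higher numbers stand for higher lipophilicity and lower numbers for lower lipophilicity. Compound 1 `N#Cc1ccc(C(=O)Nc2ccc(F)c([C@]3(C4CC4)C=C(CF)OC(N)=N3)c2)nc1` gives 2.9, and compound 2 `C[C@@]1(c2cc(NC(=O)c3ncc(C#N)cc3Cl)ccc2F)C=C(CF)OC(N)=N1` gives 2.5. Compound 2 therefore holds the lower of the two numbers, and the gap between them lies beyond the scatter of repeated measurements. These two compounds differ in more than one place, so their gap offers no measured guide to the effect of a single change.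

Compound 3 `COc1cnc(C(=O)Nc2ccc(F)c([C@]3(C)C=C(CF)OC(N)=N3)c2)cn1` has not yet been measured. It keeps the shared core of compound 2 and changes one group: 5-methoxypyrazin-2-yl in place of 3-chloro-5-cyanopyridin-2-yl on a carbonyl carbon. In words, 5-methoxypyrazin-2-yl comes in place of 3-chloro-5-cyanopyridin-2-yl on a carbonyl carbon, so the chlorine and the nitrile leave and a methoxy group arrives.

Within the data shown here, with no single-change step to lean on, the expectation rests on the structural change alone, and it is a modest fall in this assay, slightly larger than the scatter. The expected move is a number 0.40 log units lower from compound 2 to compound 3 (beyond the scatter). For compound 3 the estimated value is 2.1, with an expected range from 1.7 to 2.5.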

Compound 3, distribution coefficient: 2.7
The estimate for compound 3 lay 0.60 log units below the measured number; measured number above the stated range.
By their numbers in this assay, from the lowest: compounds 2, 3 and 1 (each within the scatter of the next, the first and the last beyond it).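

Within the data shown here, on the carbonyl carbon, 5-methoxypyrazin-2-yl in place of 3-chloro-5-cyanopyridin-2-yl gives the first single-change step in this assay, which reads a number 0.20 log units higher from compound 2 to compound 3 (within the scatter) and is the first measured guide to a change at this position. The swap is far from small on paper: the chlorine and the nitrile leave, a methoxy group arrives, and a ring with 1 hetero atom gives way to one with 2 hetero atoms, yet this read-out does not tell the two compounds apart. Nothing measured here gives a reason for this result.

Going by these compounds, the chlorine, the nitrile, the methoxy group and the extra ring nitrogen all change in a single step, so what each one contributes on its own stays open, and the two effects could be either small or opposed. On these data alone, it also remains open whether the same position would stay within the scatter with a different group on the ring, such as an amine or an ethoxy group, which has a longer chain than methoxy.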